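A few compounds are considered here, and "the series" means these few. Any claim that something is new, unique, unknown or untested is made for them only; others in the source may bear on it.

Compound 1 `COc1cc(Nc2nc(C(=N)Nc3ccccc3)cc3c(-c4ccccc4)n[nH]c23)cc(OC)c1OC` carries a hydrogen on an aromatic nitrogen of its two-ring core. For the measured compounds named here, in a functional assay on MDA-MB-231 cells (Homo sapiens) for cytotoxicity, read by MTT assay, with a stated time of 72 h (on this read-out lower numbers stand for stronger inhibition and higher numbers for weaker inhibition), compound 1 gives 4500 nM, the second highest of the three numbers measured so far. Compound 2 `N=C(Nc1ccccc1)c1cc2c(-c3ccccc3)n[nH]c2c(NC2CCCCC2)n1` gives 1710 nM in this assay, and compound 3 `COc1cc(Nc2nc(C(=N)Nc3cccc(C(F)(F)F)c3)cc3c(-c4ccccc4)n[nH]c23)cc(OC)c1OC` gives 7600 nM. Two single changes to compound 1 have been measured: a 2.6-fold lower number from compound 1 to compound 2 (0.42 log units; beyond the scatter), and a 1.7-fold higher number from compound 1 to compound 3 (0.23 log units; within the scatter). Compound 4 `COc1ccc(Cn2nc(-c3ccccc3)c3cc(C(=N)Nc4ccccc4)nc(Nc4cc(OC)c(OC)c(OC)c4)c32)cc1` differs from compound 1 at a third place: 4-methoxybenzyl in place of hydrogen on an aromatic nitrogen. Going by the values given here, neither measured step touches that ring nitrogen, so neither bears directly on this change; they show only that one change elsewhere moved the number modestly, while the other left it within the scatter. No step beyond the scatter is therefore expected, with a wide range to allow for the lack of a closer comparison. For compound 4 the expected value in this assay is 5000 nM, between 1500 nM and 20000 nM, which would amount to an expected 1.1-fold higher number from compound 1 to compound 4 (0.05 log units; within the scatter).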

Compound 4, half-maximal inhibitory concentration: 42100 nM
For compound 4 the middle estimate is 8.4-fold (0.93 log units) below the measured one; the measured number lies above the stated range.
By their numbers in this assay, from the lowest: compound 2; then compounds 1 and 3 (each within the scatter of the next); then compound 4.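

Putting 4-methoxybenzyl on this aromatic nitrogen gives a 9.4-fold higher number from compound 1 to compound 4 (0.97 log units; beyond the scatter) in this assay, so this position is not a silent one: the change shifts the number towards weaker inhibition. Of the three single changes to compound 1 shown, this one moves the number furthest, which makes the ring nitrogen the most sensitive of the three places so far. Nothing measured here explains the shift.

The compounds shown leave open whether a methyl group, a plain benzyl group or a longer chain on this nitrogen would raise the number as much, and so whether the loss follows from replacing the hydrogen at all or from this particular group. They also leave open whether the same change would act alike on compound 2, with its cyclohexyl group.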